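Glutamyl dipeptide esters: cytotoxicity notes toward compound 4

The compounds below may be only part of what the source reports. "The series", "measured", "known", "first", "only" and "open" are said of these compounds alone.

compound 1 `COC(=O)CNC(=O)C(CSCc1ccc(Br)cc1)NC(=O)CCC(N)C(=O)OC` — > 50 uM (a limit)
compound 2 `COC(=O)CNC(=O)C(CSCc1ccc(Br)cc1)NC(=O)CCC(NC=O)C(=O)OC` — > 50 uM (a limit)
compound 3 `COC(=O)CNC(=O)C(CSCc1ccc(Br)cc1)NC(=O)CCC(NC(=O)OCc1ccccc1)C(=O)O` — > 50 uM (a limit)

In a functional assay on K562 cells (Homo sapiens) for cytotoxicity (on this read-out higher numbers stand for weaker inhibition and lower numbers for stronger inhibition), compound 1 gives only a limit, > 50 uM. Compound 2 likewise gives a limit, > 50 uM. Compound 3 also gives a limit, > 50 uM. The step that the two limits leave unreadable from compound 1 to compound 2 cannot be sized, as both of its ends are limits. Every value shown in this assay is the same limit: the limit of > 50 uM in this assay, at which 3 of the 3 values shown sit. Compound 3 therefore stands nowhere distinguishable from compound 1 or compound 2; none of the three is readable as stronger or weaker.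

Compound 4 `COC(=O)CNC(=O)C(CSCc1ccc(Br)cc1)NC(=O)CCC(NC(=O)OCc1ccccc1)C(=O)OC` differs from compound 3 by methyl in place of hydrogen on an oxygen next to a carbonyl group. For the measured compounds named here, no measured step bears on this change; the only step available is unreadable. Compound 1 and compound 2 already carry a methoxycarbonyl at that position and both sit at the limit, as does compound 3 with the carboxy. It is therefore expected that compound 4 will again reach only the limit, with a step that the limit leaves unreadable from compound 3 to compound 4 expected as no readable step. The estimate for compound 4 is 80 uM, within a range of 30 uM to 300 uM.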

Compound 4, concentration for 50% inhibition: 16.7 uM
The estimate for compound 4 lay 4.8-fold (0.68 log units) above the measured number; the whole stated range lies above it.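

In this assay, methyl in place of hydrogen on an oxygen next to a carbonyl group gives an at least 2.9-fold lower number from compound 3 to compound 4 (0.47 log units; beyond the scatter), so this position can register a change once benzyloxycarbonyl sits on the amine nitrogen. With the methoxycarbonyl kept, benzyloxycarbonyl in place of hydrogen on that nitrogen gives an at least 2.9-fold lower number from compound 1 to compound 4 (0.47 log units; beyond the scatter), and benzyloxy in place of hydrogen on a carbonyl carbon gives an at least 2.9-fold lower number from compound 2 to compound 4 (0.47 log units; beyond the scatter). Among these compounds, only compound 4, carrying both methoxycarbonyl and benzyloxycarbonyl, gives a readable number, while the others stay at the limit: the limit of > 50 uM in this assay, at which 3 of the 4 values shown sit.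

As far as these compounds go, the full size of each step stays open, since one end of each is a limit. Also open, from the compounds shown here alone, is how an ethyl ester or a primary amide at this position, or an acetyl group on the amine nitrogen, would read.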